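Cyanomethyl for Carboxymethyl on a Shared Core

This account rests on a few compounds, and the source may have more. Where it says the series, first, only, none or still open, it means among the compounds named here.

Measured in an assay on HEK293 cells for binding affinity to adenosine receptor A2b (Homo sapiens), read by radioligand binding; a higher number here means a weaker inhibitor, a lower number a stronger inhibitor:
Compound 1 `CC(=O)OCCn1cnc2c1c(=O)n(C)c(=O)n2C` — 23200 nM
Compound 2 `C=CCn1c(=O)c2c(ncn2C)n(CC=C)c1=O` — 3390 nM
Compound 3 `Cn1cnc2c1c(=O)n(CC(=O)O)c(=O)n2C` — 23500 nM

Among these three, compound 3 gives the highest number. Compound 1 sits within the usual scatter of compound 3, so the two cannot be ordered. Compound 2 gives a number well below that of compound 3, beyond the scatter.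

Compound 4 `Cn1cnc2c1c(=O)n(CC#N)c(=O)n2C` differs from compound 3 by cyano in place of carboxy on a saturated chain carbon bound to an aromatic nitrogen. Among the measured compounds shown here, no pair of measured compounds differing in only one place is available, so the size of this step has no direct precedent here. Compound 4 is expected to show a modest fall in number, estimated as a 2.0-fold lower number from compound 3 to compound 4 (0.29 log units; within the scatter). Compound 4 is therefore estimated at 12000 nM in this assay, with a likely range from 3000 nM to 40000 nM.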

Compound 4, inhibition constant: 21600 nM
Estimate against measurement, compound 4: 1.8-fold (0.26 log units) below; measured number inside the range.
By their numbers in this assay, from the lowest: compound 2; then compounds 4, 1 and 3 (each within the scatter of the next).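

In this assay, among the compounds shown here, cyano in place of carboxy on a saturated chain carbon bound to an aromatic nitrogen gives a 1.1-fold lower number from compound 3 to compound 4 (0.04 log units; within the scatter), the only step here between compounds that differ in one place. At this position, carboxymethyl and cyanomethyl cannot be told apart, even though the change removes the hydrogen-bond donor of carboxy. No evidence at hand bears on this result. The compounds shown leave open whether an amide or an amine on this chain carbon would give a number in the same region. They also leave open what a longer chain would give.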